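The source may report more compounds than this note shows. Statements on the series, on what has been measured and on what is new or still open speak of the compounds shown alone.

Measured so far:
compound 1, `c1ccc(CNC2CCN(CCCc3c[nH]c4ccc(-n5cnnc5)cc34)CC2)cc1`, 7.6 nM;
compound 2, `OCCC(NC1CCN(CCCc2c[nH]c3ccc(-n4cnnc4)cc23)CC1)c1ccccc1`, 5.1 nM;
compound 3, `CC(C)=CCN(C)C1CCN(CCCc2c[nH]c3ccc(-n4cnnc4)cc23)CC1`, 1.8 nM.

These three compounds share a core and differ only in the group on a saturated ring carbon. Their activity was measured in an assay on CHO cells for agonist activity at 5-hydroxytryptamine receptor 1D (Homo sapiens), read by GTPgammaS binding; on this read-out higher numbers stand for an effect only at larger amounts of compound and lower numbers for an effect already at smaller amounts. Compound 3 gives the lowest number of the three in this assay: compound 2 lies a 2.8-fold lower number from compound 2 to compound 3 (0.45 log units; beyond the scatter) away and compound 1 a 4.2-fold lower number from compound 1 to compound 3 (0.63 log units; beyond the scatter) away, both steps beyond the scatter, while the step of a 1.5-fold lower number from compound 1 to compound 2 (0.17 log units; within the scatter) is within it.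

Compound 4, `c1ccc(CNCC2CCN(CCCc3c[nH]c4ccc(-n5cnnc5)cc34)CC2)cc1`, has not yet been measured. It differs from compound 3 in one place: (benzylamino)methyl in place of methyl(3-methylbut-2-en-1-yl)amino on a saturated ring carbon. The entering group is close to the benzylamino of compound 1, now set one carbon further from the ring. Going by the values given here, the most relevant step is the one from compound 1 to compound 3, a 4.2-fold lower number from compound 1 to compound 3 (0.63 log units; beyond the scatter), which the change from compound 3 to compound 4 largely reverses. A step of roughly that size back toward a higher number is therefore expected, a 4.4-fold higher number from compound 3 to compound 4 (0.65 log units; beyond the scatter). For compound 4 the estimate in this assay is 8 nM, with a range from 3 nM to 25 nM.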

Compound 4, half-maximal effective concentration: 5.6 nM
The estimate for compound 4 lay 1.4-fold (0.15 log units) above the measured number; measured number inside the range.
By their numbers in this assay, from the lowest: compound 3; then compounds 2, 4 and 1 (each within the scatter of the next).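

Set one carbon further from the ring as (benzylamino)methyl, the benzylamino group of compound 1 gives no readable change in this assay, with a 1.4-fold lower number from compound 1 to compound 4 (0.13 log units; within the scatter) lying within the scatter. With a 1.1-fold higher number from compound 2 to compound 4 (0.04 log units; within the scatter) also within the scatter and a 3.1-fold higher number from compound 3 to compound 4 (0.49 log units; beyond the scatter) beyond it, the three compounds with an aromatic ring in this group sit together, and compound 3, with methyl(3-methylbut-2-en-1-yl)amino, stands apart with the lowest number. Nothing shown gives a measured reason for this.

Compound 3 differs from compound 4 at once in its double bond, its lack of an aromatic ring and its lack of a hydrogen-bond donor, so the compounds shown cannot say which of these goes with its lower number. A methyl(benzyl)amino or a simple dimethylamino group at this position would help to separate these features.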